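Replacing the Dichlorophenyl Urea Arm of Compound 3 with a Pyridine

A few compounds are considered here, and "the series" means these few. Any claim that something is new, unique, unknown or untested is made for them only; others in the source may bear on it.

Compound 1, `COc1ccc(-c2cc(NNC(=O)Nc3cc(Cl)nc(Cl)c3)nc3c2cnn3C)cc1`, gives 520 nM in an assay on isolated protein for binding affinity to sphingosine 1-phosphate receptor 2 (Homo sapiens), read by surface plasmon resonance; a higher number here means weaker binding, a lower number tighter binding.
Compound 2, `Cn1nc(C(F)(F)F)c2c(-c3ccccc3)cc(NNC(=O)Nc3cc(Cl)nc(Cl)c3)nc21`, gives 940 nM in this assay.
Compound 3, `Cn1ncc2c(-c3ccc(F)cc3)cc(NNC(=O)Nc3cc(Cl)cc(Cl)c3)nc21`, gives 4980 nM in this assay.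

Compound 3 has the highest number of the three. Its nearest neighbour is compound 2, whose number is lower by a margin beyond the scatter, and compound 1 lies further still, also beyond the scatter. The next compound, compound 4, `COc1cc(NC(=O)NNc2cc(-c3ccc(F)cc3)c3cnn(C)c3n2)cc(Cl)n1`, differs from compound 3 in a single spot: 2-chloro-6-methoxypyridin-4-yl in place of 3,5-dichlorophenyl on an amide-type nitrogen. Within the data shown here, compounds 1 and 2 both carry a chlorinated pyridine rather than a dichlorophenyl on that same urea nitrogen, and both show lower numbers than compound 3, though no direct pair isolates that swap, and compound 4 also trades one chlorine for a methoxy. Compound 4 is therefore expected to bind somewhat tighter than compound 3, with the step from compound 3 to compound 4 estimated at a 4.2-fold lower number from compound 3 to compound 4 (0.62 log units; beyond the scatter). The expected value for compound 4 in this assay is 1200 nM, within a range from 350 nM to 4000 nM.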

Compound 4, dissociation constant: 1650 nM
The estimate for compound 4 lay 1.4-fold (0.14 log units) below the measured number; the measured number falls inside the stated range.
By their numbers in this assay, from the lowest: compounds 1, 2 and 4 (each within the scatter of the next, the first and the last beyond it); then compound 3.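

Among these compounds, the step of a 3.0-fold lower number from compound 3 to compound 4 (0.48 log units; beyond the scatter) in this assay gives the first direct reading at this position, on the amide-type nitrogen, since compound 1 and compound 2 each differ from compound 3 in more than one place. It shows that 2-chloro-6-methoxypyridin-4-yl is tolerated in place of 3,5-dichlorophenyl and gives a modest gain in binding, beyond the scatter. Nothing measured here explains that gain.

The swap brings in a ring nitrogen and a methoxy group while removing a chlorine, so the compounds shown cannot divide the step among these changes. Also open, from the compounds shown here alone, is how binding would respond on this core if an ethoxy group, a dimethylamino group or a hydroxyl group stood in place of the methoxy.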